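A few compounds are considered here, and "the series" means these few. Any claim that something is new, unique, unknown or untested is made for them only; others in the source may bear on it.

Measured so far:
compound 1 `CCCOc1ccc(C(=O)NNc2c(Br)cccc2Br)cc1` gives > 100000 nM
compound 2 `CCOc1ccc(C(=O)NNc2c(Br)cc(Br)cc2Br)cc1` gives 54800 nM

In a toxicity assay on MDCK cells (Canis lupus familiaris) for cytotoxicity, read by CCK-8 assay, with a stated time of 48 h (on this read-out lower numbers stand for higher toxicity in this test and higher numbers for lower toxicity in this test), compound 1 gives only a limit, > 100000 nM, not a number; it sits at the limit of > 100000 nM in this assay, at which 1 of the 2 values shown sits. Compound 2 carries one more bromine on its ring than compound 1 and an ethoxy group where compound 1 carries a propoxy group; in this assay compound 2 gives 54800 nM. Among the compounds with values here, no step between two measured compounds that differ in only one place is available here, so nothing is known about how any single change moves this read-out.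

Compound 3 `O=C(NNc1c(Br)cccc1Br)c1ccc(O)cc1` is not yet measured. It differs from compound 1 in one place: hydrogen in place of propyl on an oxygen on an aromatic ring, that is, propoxy becomes hydroxy. Within the data shown here, since compound 1 already stands at a limit and no measured step says what this change does, the step of a number no higher from compound 1 to compound 3 (the limit leaves the size open) is expected to be none beyond the scatter, in either direction. Compound 3 is therefore estimated at 100000 nM in this assay, within 40000 nM to 300000 nM, with a fair chance that only a limit is reported again.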

Compound 3, half-maximal cytotoxic concentration: > 100000 nM
Compound 3 ended at the assay's limit; the forecaster's own chance of this, stated with the estimate: 60%; the middle value sits exactly at the limit.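

In this assay, compound 1 and compound 3 each stop at a limit and not at a number, so the change from propoxy to hydroxy gives no step that can be read: the limit of > 100000 nM in this assay, at which 2 of the 3 values shown sit.

As far as these compounds go, how far either compound lies past that limit, and whether the change moves this read-out at all, stays open.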